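The compounds below may be only part of what the source reports. "The series", "measured", "known", "first", "only" and "open" are said of these compounds alone.

In a functional assay on Huh-7 cells (Homo sapiens) for antiproliferative activity, read by CCK-8 assay, with a stated time of 72 h (a lower number here means a stronger inhibitor of growth, a higher number a weaker inhibitor of growth), compound 1 (`CCC1C(=O)N(C)c2cnc(Nc3ccc(S(=O)(=O)NC)cc3)nc2N1c1ccn(C)n1`) gives 11900 nM. Compound 3 (`CCC1C(=O)N(C)c2cnc(-n3ccc4cc(C(=O)NC)ccc43)nc2N1c1ccn(C)n1`) gives 13200 nM, which lies within the usual scatter of compound 1, so these two cannot be told apart here. Compound 2 (`CC[C@@H]1C(=O)N(C)c2cnc(Nc3ccc(S(=O)(=O)NC)cc3)nc2N1C1CCCC1`) gives 99 nM, a far lower number and well beyond the scatter, which makes compound 1 a much weaker growth inhibitor than compound 2. No two of these three compounds differ in only one place, so the data give no direct measure of any single change.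

Compound 4 (`CCCNS(=O)(=O)c1ccc(Nc2ncc3c(n2)N(c2ccn(C)n2)C(CC)C(=O)N3C)cc1`) is compound 1 with one small alteration, methylsulfamoyl to propylsulfamoyl. The counted difference is ethyl in place of hydrogen on a saturated chain carbon bound to a sulfonamide nitrogen.

With no measured single change to go on, no step beyond the scatter is expected in this assay, and no clear direction can be given. One weak hint supports this: compound 3, at 13200 nM, carries no methylsulfamoyl group at all, yet it stays close to compound 1. The expected change is small, as a 1.2-fold lower number from compound 1 to compound 4 (0.08 log units; within the scatter) is only an estimate. For compound 4 the estimated value is 10000 nM, with an expected range from 4000 nM to 25000 nM.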

Compound 4, concentration for 50% growth inhibition: 8880 nM
Beside the measured number, compound 4's estimate is 1.1-fold (0.05 log units) above it; the measured number falls inside the stated range.
By their numbers in this assay, from the lowest: compound 2; then compounds 4, 1 and 3 (each within the scatter of the next).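

Among the compounds shown here, this is the first comparison in this assay between two compounds that differ in only one place, and it gives a measured size for a change at the sulfonamide nitrogen: a 1.3-fold lower number from compound 1 to compound 4 (0.13 log units; within the scatter). The step lies within the usual scatter, so the methylsulfamoyl and propylsulfamoyl forms cannot be told apart here, and on this core, with its ethyl and methylpyrazole groups kept as they are, ethyl in place of hydrogen on the saturated chain carbon bound to a sulfonamide nitrogen produces no readable effect on growth inhibition. No independent measurement is available to explain this result.

This single comparison covers only one added chain on one background, so it cannot show whether a much longer chain such as octyl, or a chain ending in an amine or a carboxylic acid, would also stay within the scatter. It also leaves open whether the same change would give a similar result on compound 2, whose cyclopentyl group sets it apart from compound 1 and whose number lies far lower.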